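Two sulfonamides at the limit, and a third to test

This account rests on a few compounds, and the source may have more. Where it says the series, first, only, none or still open, it means among the compounds named here.

The compounds here are sulfonamides measured in an assay on isolated protein for inhibition of malate dehydrogenase, mitochondrial (Sus scrofa), with stated times of 45 min and 30 min; a lower number here means a stronger inhibitor, a higher number a weaker inhibitor. Compound 1 `O=S(=O)(Nc1ccc(-c2nc3ccccc3o2)cc1)c1cccc(F)c1` gives > 63000 nM, which is a limit of the assay rather than a number. Compound 2 `Cc1ccccc1S(=O)(=O)Nc1ccc2oc(-c3ccccc3)nc2c1` gives > 63000 nM, again a limit and not a number. So compound 2 stands where the only other measured compound stands: both values sit at the limit (the limit of > 63000 nM in this assay, at which 2 of the 2 values shown sit), and nothing separates the two.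

Compound 3 `CCc1ccc(S(=O)(=O)Nc2ccc3oc(-c4ccccc4)nc3c2)cc1` is the next compound, not yet measured. It differs from compound 2 in one place (4-ethylphenyl in place of 2-methylphenyl on a sulfonyl sulfur). Within the data shown here, since both measured compounds sit at the limit, there is no measured step to show what such a change does, and the expectation rests on that limit alone.

The step from compound 2 to compound 3 is expected to be none beyond the scatter, with compound 3 most likely remaining at the limit a step that the limit leaves unreadable from compound 2 to compound 3. For compound 3 the estimated value is 90000 nM, with a range from 25000 nM to 400000 nM.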

Compound 3, half-maximal inhibitory concentration: > 63000 nM
Compound 3: no number, only a limit; the forecaster's own chance of this, stated with the estimate: 75%; the middle value lies beyond the limit too.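

In this assay compound 3 gives > 63000 nM, a limit of the assay and not a number. Compound 2 also has only a limit, so the swap of 2-methylphenyl for 4-ethylphenyl gives no readable step between compound 2 and compound 3. What would bring these sulfonamides to a measurable number stays open, with every value at one limit: the limit of > 63000 nM in this assay, at which 3 of the 3 values shown sit.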